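This account rests on a few compounds, and the source may have more. Where it says the series, first, only, none or still open, it means among the compounds named here.

Measured so far:
compound 1 `NC(=O)c1c(NC(=O)c2ccccc2Br)sc2c1CCN(C(=S)Nc1ccccc1F)C2`: > 50000 nM
compound 2 `NC(=O)c1c(NC(=O)c2ccccc2Br)sc2c1CCN(C(=S)Nc1ccccc1Br)C2`: 24700 nM
compound 3 `NC(=O)c1c(NC(=O)c2ccccc2C(F)(F)F)sc2c1CCN(C(=S)Nc1ccccc1F)C2`: > 50000 nM

All three share one core and differ at two places. In a functional assay on HeLa cells (Homo sapiens) for antiproliferative activity, with a stated time of 24 h (a lower number here means a stronger inhibitor, a higher number a weaker inhibitor), compound 2 gives 24700 nM. Compound 1 gives only a limit of this assay, > 50000 nM. Compound 3 also gives only a limit of this assay, > 50000 nM.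

From compound 1 to compound 2 the change is bromo in place of fluoro on an aromatic carbon, and the step is an at least 2.0-fold lower number from compound 1 to compound 2 (0.30 log units; that floor lies within the scatter). The cores of compound 1 and compound 3 differ as trifluoromethyl in place of bromo on an aromatic carbon; the step that the two limits leave unreadable from compound 1 to compound 3 cannot be read because of the limit of > 50000 nM in this assay, at which 2 of the 3 values shown sit.

Compound 4 `NC(=O)c1c(NC(=O)c2ccccc2C(F)(F)F)sc2c1CCN(C(=S)Nc1ccccc1Br)C2` has not been measured. It differs from compound 3 by bromo in place of fluoro on an aromatic carbon, the same change at the same place as that from compound 1 to compound 2. Beside the measured step of an at least 2.0-fold lower number from compound 1 to compound 2 (0.30 log units; that floor lies within the scatter), the step of an at least 1.4-fold lower number from compound 3 to compound 4 (0.15 log units; that floor lies within the scatter) is expected to be of similar size, resting only on that one earlier pair. Since compound 3 sits at a limit, > 50000 nM, the new value may also end as a limit. Compound 4 is expected to give about 35000 nM, within 12000 nM to 100000 nM.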

Compound 4, half-maximal inhibitory concentration: > 50000 nM
Compound 4: only a limit was reported; the forecaster's own chance of this, stated with the estimate: 45%; middle value at least 1.4-fold (0.15 log units) from the limit.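

In this assay compound 4 gives > 50000 nM, which is a limit of the assay and not a number. The step from compound 3 to compound 4, like the other steps that join two limits, cannot be read because these compounds reach no measured value: the limit of > 50000 nM in this assay, at which 3 of the 4 values shown sit. The one readable new step, with trifluoromethyl in place of bromo on an aromatic carbon, is an at least 2.0-fold higher number from compound 2 to compound 4 (0.30 log units; that floor lies within the scatter), so bromo in place of fluoro is neither shown to carry over to the core of compound 3 nor shown to fail there.

Among the compounds shown, only compound 2 gives a measured number in this assay, 24700 nM, so every readable comparison rests on that single value. From the compounds shown here alone, it remains open how the series would respond at these two places to other groups, such as a methoxy group, an amine or a carboxylic acid, and whether any of them would give a measured value rather than a limit.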